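The compounds below may be only part of what the source reports. "The series", "measured", "known", "first", "only" and "open" are said of these compounds alone.

Measured in a functional assay on the whole organism (strain Albino) for inhibition, with Rattus norvegicus as the target, with stated times of 1 h and 2 h, at a dose of 20 mg/kg by the oral route; a lower number here means less inhibition, a higher number more inhibition at the dose given (going by the name of the read-out):

Compound 1 `O=C(O)CCC1=C(c2ccc(Cl)cc2)NC(=S)NC1c1ccco1`: 17.9%
Compound 2 `O=C(O)CCC1=C(c2ccccc2)NC(=S)NC1c1ccco1`: 21.8%
Compound 3 `Cc1ccc(C2=C(CCC(=O)O)C(c3ccco3)NC(=S)N2)cc1`: 28.1%

Compound 3 holds the highest of the three numbers; its gap to compound 2 is within the scatter, a number 6.3 percentage points higher from compound 2 to compound 3 (within the scatter), while its gap to compound 1 is beyond it, a number 10.2 percentage points higher from compound 1 to compound 3 (beyond the scatter). Compound 4 `COc1cc(C2NC(=S)NC(c3ccc(C)cc3)=C2CCC(=O)O)ccc1O` differs from compound 3 in one place: 4-hydroxy-3-methoxyphenyl in place of furan-2-yl on a saturated ring carbon. Going by the values given here, the measured steps all concern the group on the aromatic carbon, a number 3.9 percentage points higher from compound 1 to compound 2 (within the scatter) being the other one, and none of them touches the saturated ring carbon, so no measured step bears directly on this change. The step is therefore expected to stay within the scatter, a number 0.1 percentage points lower from compound 3 to compound 4 (within the scatter). Compound 4 is estimated at 28%, in the range 15% to 42%.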

Compound 4, a percentage reported as inhibition, in the whole organism at one dose (the size of the read-out at that dose, not a potency): 1.57%
Estimate against measurement, compound 4: 26.4 percentage points above, outside the stated range (below it).
By their numbers in this assay, from the lowest: compound 4; then compounds 1, 2 and 3 (each within the scatter of the next, the first and the last beyond it).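

The saturated ring carbon turns out to matter in this assay: swapping furan-2-yl for 4-hydroxy-3-methoxyphenyl there gives a number 26.5 percentage points lower from compound 3 to compound 4 (beyond the scatter) and leaves almost no inhibition at the dose given. This step is larger than any change on the aromatic carbon, the biggest of which was a number 10.2 percentage points higher from compound 1 to compound 3 (beyond the scatter) at that other site. Nothing available explains the drop. Open, on these data alone, is whether the loss comes from the six-membered ring itself or from its hydroxy and methoxy groups, which an unsubstituted phenyl or a thiophen-2-yl on this carbon could help separate.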